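Permeability of three aryloxy acids and one untested analogue

The compounds below may be only part of what the source reports. "The series", "measured", "known", "first", "only" and "open" are said of these compounds alone.

The measured compounds in an ADME assay for permeability, using PAMPA, with a stated time of 4 h (on this read-out lower numbers stand for lower permeability and higher numbers for higher permeability), are:
compound 1 `Cn1c(COc2cccc(C(=O)O)c2)nc2ccc(Oc3ccc(Cl)c(F)c3)nc21` gives 25.6 10^-6 cm/s;
compound 2 `Cc1ccc(Oc2cc3c(cn2)nc(COc2cccc(C(=O)O)c2)n3C)cc1` gives 6.8 10^-6 cm/s;
compound 3 `Cn1c(COc2cccc(C(=O)O)c2)nc2ccc(Oc3ccc(Cl)cn3)cc21` gives 16.2 10^-6 cm/s.

Compound 3 stands second highest of the three numbers. Its nearest neighbour is compound 1, whose number lies within the scatter of compound 3, so no order between them can be read. Compound 2 is the furthest from compound 3 and lies beyond the scatter, so compound 3 is clearly the more permeable of that pair.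

From the compounds shown here alone, compound 4 `Cc1ccc(C)c(Oc2ccc3nc(COc4cccc(C(=O)O)c4)n(C)c3c2)n1` is untested. Relative to compound 3 the change is 3,6-dimethylpyridin-2-yl in place of 5-chloropyridin-2-yl on an oxygen on an aromatic ring.

Within the data shown here, no measured pair shows this exchange, so the direction can only be guessed. Compound 4 is expected to differ from compound 3 by a 1.2-fold lower number from compound 3 to compound 4 (0.06 log units; within the scatter), a step within the scatter. Compound 4 is therefore estimated at 14 10^-6 cm/s, between 7 10^-6 cm/s and 28 10^-6 cm/s.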

Compound 4, apparent permeability: 11 10^-6 cm/s
The estimate for compound 4 lay 1.3-fold (0.10 log units) above the measured number; low and high end bracket the measured number.
By their numbers in this assay, from the lowest: compounds 2, 4, 3 and 1 (each within the scatter of the next, the first and the last beyond it).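

In this assay the exchange of 5-chloropyridin-2-yl for 3,6-dimethylpyridin-2-yl on an oxygen on an aromatic ring gives a 1.5-fold lower number from compound 3 to compound 4 (0.17 log units; within the scatter) and is the only step shown at this position. Within the scatter, the read-out does not separate the chloro-substituted and dimethyl-substituted pyridines here. Nothing measured accounts for the result.

The compounds shown leave open whether a single methyl group or the chlorine kept alongside a methyl group would read the same. They also leave open how a methoxy group or an amine on this pyridine ring would read.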